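This account rests on a few compounds, and the source may have more. Where it says the series, first, only, none or still open, it means among the compounds named here.

Measured so far:
- compound 1, `Cc1nc(N)sc1CCCNC(=N)NC(=O)C[C@H](C)C1CCCCC1`: 28.8 nM
- compound 2, `C[C@H](CC(=O)NC(=N)NCCCc1c[nH]cn1)c1ccccc1`: 120 nM
- compound 3, `Cc1nc(N)sc1CCCNC(=N)NC(=O)CC(C)c1ccccc1`: 50.1 nM

Compound 3 gives 50.1 nM in an in vitro functional assay on Sf9 cells for agonist activity at histamine H2 receptor (Homo sapiens), read by GTPgammaS binding (a higher number here means that more compound is needed for the effect, a lower number that less compound is needed), the second highest of the three numbers. Its nearest neighbour is compound 1, which lies lower by a 1.7-fold higher number from compound 1 to compound 3 (0.24 log units; within the scatter), a gap within the scatter; furthest away is compound 2, whose value stands beyond the scatter above it.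

Compound 4, `Cc1nc(N)sc1CCCNC(=N)NC(=O)C[C@@H](C)C1CCCCC1`, has not been measured. It differs from compound 3 as follows: 1-cyclohexylethyl in place of 1-phenylethyl on a saturated chain carbon bound to a carbonyl carbon. For the measured compounds named here, the one measured step that bears on this change is the step from compound 1 to compound 3, a 1.7-fold higher number from compound 1 to compound 3 (0.24 log units; within the scatter), which runs the opposite way and stays within the scatter. On that basis no step beyond the scatter is expected from compound 3 to compound 4, with the entering group carrying 1 defined stereocentre, so the answer need not simply repeat compound 1. The step from compound 3 to compound 4 is estimated at a 1.3-fold lower number from compound 3 to compound 4 (0.10 log units; within the scatter). Compound 4 is expected to give about 40 nM in this assay, within a range from 10 nM to 160 nM.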

Compound 4, half-maximal effective concentration: 20.4 nM
For compound 4 the middle estimate is 2.0-fold (0.29 log units) above the measured one; measured number inside the range.
By their numbers in this assay, from the lowest: compounds 4, 1 and 3 (each within the scatter of the next, the first and the last beyond it); then compound 2.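

In this assay, for the compounds shown here, the change to 1-cyclohexylethyl from 1-phenylethyl gives a 2.5-fold lower number from compound 3 to compound 4 (0.39 log units; beyond the scatter) and so, though modest, it is the first step at this place to pass the scatter, whereas the earlier step between these two groups stayed within it. The two 1-cyclohexylethyl compounds show a 1.4-fold lower number from compound 1 to compound 4 (0.15 log units; within the scatter) and so opposite drawn configurations at the saturated chain carbon leave the number within the scatter. That pair can be read as a comparison of configurations only with one reservation: the fact that one of compounds 1 and 4 is drawn with a defined configuration and the other without, at the place where they differ.

The compounds shown leave open how a cyclopentyl ring, a tert-butyl group or a longer chain would behave at this place. They also leave open whether 1-cyclohexylethyl would give a similar step on the core of compound 2.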